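Methyl on the core: a step from compound 1

The compounds below may be only part of what the source reports. "The series", "measured", "known", "first", "only" and "open" are said of these compounds alone.

Compound 1 (`O=c1cc(Cc2c(F)cccc2F)nc(SCc2ccccc2)[nH]1`) is the starting point in an ADME assay on MT4 cells (Homo sapiens) for cytotoxicity, read by MTT assay; on this read-out higher numbers stand for lower toxicity in this test and lower numbers for higher toxicity in this test. In this assay compound 1 gives > 73000 nM, which is a limit and not a number. Compound 3 (`O=C(CSc1nc(Cc2c(F)cccc2F)cc(=O)[nH]1)c1ccc(Cl)cc1`) gives > 61000 nM, also a limit. Among the measured compounds shown here, compound 2 (`O=c1cc(Cc2c(F)cccc2F)nc(SCCCc2ccccc2)[nH]1`) is the only one with a true number, at 32000 nM.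

Compound 4 (`Cc1c(Cc2c(F)cccc2F)nc(SCc2ccccc2)[nH]c1=O`) carries methyl in place of hydrogen on an aromatic carbon.

For the measured compounds named here, no measured step touches this carbon. All three fall on the saturated chain carbon bound to a sulfur. Phenethyl in place of phenyl gives an at least 2.2-fold lower number from compound 1 to compound 2 (0.35 log units; beyond the scatter). (4-Chlorophenyl)carbonyl in place of phenyl gives a step that the two limits leave unreadable from compound 1 to compound 3, and in place of phenethyl it gives an at least 1.9-fold higher number from compound 2 to compound 3 (0.28 log units; that floor lies within the scatter).

These steps offer only a loose guide, and the sole readable one, to compound 2 with an at least 2.2-fold lower number from compound 1 to compound 2 (0.35 log units; beyond the scatter), is modest. A step beyond the scatter is therefore not firmly expected, though a modest fall in the number is possible, and another limit may be reported. The estimated step is an at least 1.1-fold lower number from compound 1 to compound 4 (0.05 log units; that floor lies within the scatter). For compound 4 the expected value is 65000 nM, with an estimated range of 25000 nM to 150000 nM.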

Compound 4, half-maximal cytotoxic concentration: > 70000 nM
Compound 4: a limit, no number; the forecaster's own chance of this, stated with the estimate: 55%; at least 1.0-fold (0.03 log units) between middle value and limit.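

Compound 1 and compound 4 both give limits and not numbers in this assay, and the step of methyl in place of hydrogen on an aromatic carbon between them cannot be read. The compounds shown leave open whether this methyl changes the read-out at all.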